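Swapping the aryl group for furan-2-yl: compound 3 to compound 4

The source may report more compounds than this note shows. Statements on the series, on what has been measured and on what is new or still open speak of the compounds shown alone.

Measured so far:
Compound 1 `O=C1N=C(C2C(=O)c3ccccc3C2=O)CC(c2ccccc2[N+](=O)[O-])N1`: 11%
Compound 2 `O=C1N=C(C2C(=O)c3ccccc3C2=O)CC(c2cccc([N+](=O)[O-])c2)N1`: 27%
Compound 3 `O=C1N=C(C2C(=O)c3ccccc3C2=O)CC(c2ccc(Cl)cc2)N1`: 15%

All three share one core and differ only in the aromatic group on a saturated ring carbon. In a functional assay on the whole organism for inhibition, with Rattus norvegicus as the target, read by paw edema, with stated times of 30 min and 1 h, at a dose of 10 mg/kg by the oral route (on this read-out lower numbers stand for less inhibition and higher numbers for more inhibition at the one dose given (going by the name of the read-out)), compound 3 gives 15%, the second highest of the three numbers. The neighbouring steps are a number 4 percentage points higher from compound 1 to compound 3 (within the scatter) and a number 12 percentage points lower from compound 2 to compound 3 (beyond the scatter). Among the measured compounds shown here, the one step that clearly moved the number, a number 16 percentage points higher from compound 1 to compound 2 (beyond the scatter), also only changed the group at this spot.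

Compound 4 `O=C1N=C(C2C(=O)c3ccccc3C2=O)CC(c2ccco2)N1` makes a further change at the same spot: furan-2-yl in place of 4-chlorophenyl on a saturated ring carbon. For the measured compounds named here, no measured step exchanges a six-membered aromatic ring for a five-membered one, so the three steps at this position are the only guide, and their spread is small. A step of no change at the digits printed from compound 3 to compound 4 (within the scatter) is therefore expected, meaning no change beyond the scatter. Compound 4 is estimated at 15%, within 4% to 28%.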

Compound 4, a percentage reported as inhibition, in the whole organism at one dose (the size of the read-out at that dose, not a potency): 18%
Compound 4: the middle estimate sits 3 percentage points below what was measured; the range from low to high includes it.
By their numbers in this assay, from the lowest: compounds 1, 3, 4 and 2 (each within the scatter of the next, the first and the last beyond it).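

In this assay, a ring of a new kind at this position, the five-membered aromatic furan-2-yl with its hydrogen-bond acceptor, does not shift the number beyond the scatter from any earlier compound. The three new steps are a number 3 percentage points higher from compound 3 to compound 4 (within the scatter), a number 9 percentage points lower from compound 2 to compound 4 (within the scatter) and a number 7 percentage points higher from compound 1 to compound 4 (within the scatter), so compound 4 cannot be told apart from any of the three, even though the two ends remain separated: a number 16 percentage points higher from compound 1 to compound 2 (beyond the scatter). No measurement here gives a reason for this result.

Every compound shown carries an aromatic ring at this position, so it remains open how the number would respond to an amine, a carboxylic acid or a longer alkyl chain there. Each number also comes from a single dose, which leaves the potency of these compounds open.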